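Guanidine Side Chain on a Longer Acyl Nucleoside

The source may report more compounds than this note shows. Statements on the series, on what has been measured and on what is new or still open speak of the compounds shown alone.

Measured compounds:
Compound 1 `CCCCCCCCCC(=O)N[C@H](C(=O)Nc1ccn([C@H]2O[C@@H](CO)[C@H](O)[C@H]2O)c(=O)n1)C(C)C` gives 4990 nM in a functional assay on HeLa cells (Homo sapiens) for cytotoxicity, read by MTT assay, with a stated time of 48 h; on this read-out higher numbers stand for weaker inhibition and lower numbers for stronger inhibition.
Compound 2 `CCCCCCCCCC(=O)N[C@@H](CCCNC(=N)N)C(=O)Nc1ccn([C@H]2O[C@@H](CO)[C@H](O)[C@H]2O)c(=O)n1` gives 6000 nM in this assay.
Compound 3 `CCCCCCCCCCCCCC(=O)N[C@H](C(=O)Nc1ccn([C@H]2O[C@@H](CO)[C@H](O)[C@H]2O)c(=O)n1)C(C)C` gives 26000 nM in this assay.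

Two changes run through this set. Among the compounds with values here, the first is the swap of the amino acid side chain, (a group of 7 heavy atoms (4 carbon, 3 nitrogen; no ring) in place of a group of 3 heavy atoms (3 carbon; no ring), on a saturated chain carbon bound to an amide-type nitrogen and a carbonyl carbon); it gave a 1.2-fold higher number from compound 1 to compound 2 (0.08 log units; within the scatter). The second is the lengthening of the acyl chain, (butyl in place of hydrogen on a saturated chain carbon, nine bonds along the chain from a carbonyl carbon); it gave a 5.2-fold higher number from compound 1 to compound 3 (0.72 log units; beyond the scatter), so compound 3 stands apart from the other two.

Compound 4 `CCCCCCCCCCCCCC(=O)N[C@@H](CCCNC(=N)N)C(=O)Nc1ccn([C@H]2O[C@@H](CO)[C@H](O)[C@H]2O)c(=O)n1` has not yet been measured in this assay. It differs from compound 3 by a group of 7 heavy atoms (4 carbon, 3 nitrogen; no ring) in place of a group of 3 heavy atoms (3 carbon; no ring), on a saturated chain carbon bound to an amide-type nitrogen and a carbonyl carbon, the same change made from compound 1 to compound 2, at the same place. Since that change earlier gave a 1.2-fold higher number from compound 1 to compound 2 (0.08 log units; within the scatter), compound 4 is expected to sit close to compound 3, with an expected step of a 1.2-fold higher number from compound 3 to compound 4 (0.06 log units; within the scatter). Compound 4 is estimated at 30000 nM, within a range from 14000 nM to 65000 nM. This rests on one pair only, compound 1 and compound 2, and the result for compound 4 will show whether the change behaves alike on the longer acyl chain.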

Compound 4, half-maximal inhibitory concentration: 32000 nM
Compound 4: middle estimate off by 1.1-fold (0.03 log units), on the low side; measured number inside the range.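

In this assay, putting the guanidine side chain in place of isopropyl on the longer acyl chain gave a 1.2-fold higher number from compound 3 to compound 4 (0.09 log units; within the scatter) and so matched the step seen on the shorter acyl chain: the same change on two cores in this assay, a 1.2-fold higher number (0.08 log units; within the scatter) from compound 1 to compound 2 and a 1.2-fold higher number (0.09 log units; within the scatter) from compound 3 to compound 4, 1.0-fold (0.01 log units) apart, within the scatter of two such steps. The butyl extension of the acyl chain also carried over, giving a 5.3-fold higher number from compound 2 to compound 4 (0.73 log units; beyond the scatter) with the guanidine side chain, in agreement with its step on the isopropyl side chain: the same change on two cores in this assay, a 5.2-fold higher number (0.72 log units; beyond the scatter) from compound 1 to compound 3 and a 5.3-fold higher number (0.73 log units; beyond the scatter) from compound 2 to compound 4, 1.0-fold (0.01 log units) apart, within the scatter of two such steps. Across these four compounds, each change therefore gave much the same step on either core, but this rests on only two pairs per change in one cell assay, and it does not show that the agreement extends to other side chains or acyl lengths, nor does it explain the steps.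

The compounds shown leave open whether a side chain ending in a primary amine or a carboxylic acid would behave alike. They also leave open how a shorter or still longer acyl chain would behave on either side chain.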